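Notes before the next measurement: compound 4 in the series

The source may report more compounds than this note shows. Statements on the series, on what has been measured and on what is new or still open speak of the compounds shown alone.

Measured in a functional assay on PC-3 cells (Homo sapiens) for antiproliferative activity, read by MTT assay, tested at 1 uM (on this read-out lower numbers stand for a weaker effect and higher numbers for a stronger effect at the one concentration tested), so far:
compound 1 `COc1cc(C2=NN(C(C)=O)C(c3cccc(F)c3)O2)cc(OC)c1OC` gives 16.5%
compound 2 `COc1ccc(C2OC(c3cc(OC)c(OC)c(OC)c3)=NN2C(C)=O)c(OC)c1` gives 69.5%
compound 3 `COc1cc(C(=O)N/N=C/c2ccccc2F)cc(OC)c1OC` gives 70.6%

Compound 2 holds the second highest of the three numbers. Compound 3 stands nearest to it, the two values lying within the usual scatter of each other, so no order between them can be read. Compound 1 stands furthest away, well beyond the scatter. For the measured compounds named here, only one pair among the measured compounds differs in a single place, and that step is a number 53 percentage points higher from compound 1 to compound 2 (beyond the scatter), with 2,4-dimethoxyphenyl in place of 3-fluorophenyl on a saturated ring carbon.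

Compound 4 `COc1cc(C2=NN(C(C)=O)C(c3ccccc3C(F)(F)F)O2)cc(OC)c1OC` is the next to be measured in this assay. Its change from compound 2 is 2-(trifluoromethyl)phenyl in place of 2,4-dimethoxyphenyl on a saturated ring carbon.

Going by the values given here, the measured step bearing on this is the one from compound 1 to compound 2, which is large and runs the other way: a fluorine-bearing phenyl on the saturated ring carbon replaced by the dimethoxyphenyl brought a strong rise. Compound 4 reverses that kind of swap, putting a fluorine-bearing phenyl back. A drop well beyond the scatter in this assay is therefore expected, though the new group is not the same as in compound 1, so the full size of that step need not return.

Compound 4 is estimated at 30%, within 10% to 55%. The step expected is a number 39.5 percentage points lower from compound 2 to compound 4 (beyond the scatter).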

Compound 4, a percentage reported as inhibition, at one concentration (the size of the read-out at that concentration, not a potency): -11%
Compound 4: the middle estimate sits 41 percentage points above what was measured; measured number outside the range, below it.
By their numbers in this assay, from the lowest: compound 4; then compound 1; then compounds 2 and 3 (each within the scatter of the next).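

In this assay, the saturated ring carbon separates more than a fluorine-bearing phenyl from a dimethoxyphenyl: with 2-(trifluoromethyl)phenyl entering in place of 2,4-dimethoxyphenyl, the step is a number 80.5 percentage points lower from compound 2 to compound 4 (beyond the scatter), and with it entering in place of 3-fluorophenyl, the step is a number 27.5 percentage points lower from compound 1 to compound 4 (beyond the scatter). The second step shows that the two fluorine-bearing phenyl groups do not share one level on this read-out, and compound 4 at -11% places the change at this carbon below zero on the scale. No measurement at hand accounts for either step.

The groups at this carbon differ as whole units, so the compounds shown do not separate the role of fluorine, of the methoxy groups or of where each sits on the phenyl. As far as these compounds go, how a phenyl bearing a single methoxy group, an amine or a carboxylic acid would stand at this carbon remains open, as does whether the 2-(trifluoromethyl)phenyl step would hold on another core.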